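Ring replacement on the shared core: compound 1 to compound 4

A few compounds are considered here, and "the series" means these few. Any claim that something is new, unique, unknown or untested is made for them only; others in the source may bear on it.

Compound 1 `Cc1nn(-c2nc(-c3ccc(Cl)c(Cl)c3)c(SC(C)C)s2)c(C(=O)O)c1-c1cccc(Cl)c1C` carries a 3-chloro-2-methylphenyl on the shared core. In a functional assay on BJAB cells (Homo sapiens) for antiproliferative activity, with a stated time of 4 days (on this read-out higher numbers stand for an effect only at larger amounts of compound and lower numbers for an effect already at smaller amounts), compound 1 gives 5100 nM, the highest of the three numbers in hand. Compound 2 `Cc1nn(-c2nc(-c3ccc(Cl)c(Cl)c3)c(SC(C)C)s2)c(C(=O)O)c1-c1cc(C(F)(F)F)cc(C(F)(F)F)c1` gives 1800 nM in this assay, and compound 3 `Cc1c(-c2cc(Cl)cc(Cl)c2)c(C(=O)O)nn1-c1nc(-c2cc(Cl)cc(Cl)c2)c(SC(C)C)s1` gives 2000 nM; both lie beyond the scatter below compound 1, so compound 1 is the weakest of the measured set. Going by the values given here, no two measured compounds differ in only one place, so no single step has been quantified in this assay.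

Compound 4 `Cc1nn(-c2nc(-c3ccc(Cl)c(Cl)c3)c(SC(C)C)s2)c(C(=O)O)c1-c1cccnc1` is the next compound and has not yet been measured. It differs from compound 1 in one place: pyridin-3-yl in place of 3-chloro-2-methylphenyl on an aromatic carbon. Among the compounds with values here, no measured compound carries pyridin-3-yl, and the two compounds with lower numbers than compound 1 carry other ring substituents, so the data do not fix the direction of this change on their own.

For compound 4 the step of a 1.6-fold higher number from compound 1 to compound 4 (0.20 log units; within the scatter) is expected in this assay, a rise in the number that would reach beyond the scatter, though a result within the scatter of compound 1 cannot be ruled out. The estimate for compound 4 is 8000 nM, expected to fall between 2500 nM and 25000 nM.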

Compound 4, half-maximal effective concentration: 12000 nM
For compound 4 the middle estimate is 1.5-fold (0.18 log units) below the measured one, within the range that was stated.
By their numbers in this assay, from the lowest: compounds 2 and 3 (each within the scatter of the next); then compound 1; then compound 4.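

In this assay, going by these compounds alone, the exchange of 3-chloro-2-methylphenyl for pyridin-3-yl on the shared core gives a 2.4-fold higher number from compound 1 to compound 4 (0.37 log units; beyond the scatter) and is the first single change quantified. Within the data shown here, the position on an aromatic carbon of the five-membered aromatic ring with 2 nitrogen, next to the ring atom that bears a carboxy group, therefore responds to the ring placed on it, and this exchange moves the number upward by a modest step, a direction the earlier compounds could not fix. The exchange alters several features at once, removing the chlorine and the methyl and bringing in a ring nitrogen with one hydrogen-bond acceptor, and no measurement at hand bears on the reason for the step.

The compounds shown do not separate these features, so a plain phenyl, a phenyl with only the chlorine or only the methyl, and a pyridin-3-yl carrying a chlorine would each be needed to assign the step. As far as these compounds go, whether a pyridin-4-yl or an amine on the pyridine ring behaves in the same way at this position also remains open.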